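Moving the Fluorine on a Pyridinyl Amide Substituent

A few compounds are considered here, and "the series" means these few. Any claim that something is new, unique, unknown or untested is made for them only; others in the source may bear on it.

compound 1 `CS(=O)(=O)N(CC(=O)Nc1ccccc1)c1ccccc1Cl` — 61%
compound 2 `CS(=O)(=O)N(CC(=O)Nc1ccc(F)cn1)c1ccccc1Cl` — 66%
compound 3 `CS(=O)(=O)N(CC(=O)Nc1cccnc1F)c1ccccc1Cl` — 64%

Three amides sharing the core of compound 1 have been tested in a functional assay on HEK293 cells for positive allosteric modulation of metabotropic glutamate receptor 5 (Rattus norvegicus), read by fluorescence and calcium flux; on this read-out higher numbers stand for larger maximal responses and lower numbers for smaller maximal responses. Compound 3 stands second highest of the three; its nearest neighbour is told by a number 2 percentage points lower from compound 2 to compound 3 (within the scatter), its furthest by a number 3 percentage points higher from compound 1 to compound 3 (within the scatter). Compound 4 `CS(=O)(=O)N(CC(=O)Nc1ccc(F)nc1)c1ccccc1Cl` differs from compound 3 by 6-fluoropyridin-3-yl in place of 2-fluoropyridin-3-yl on an amide-type nitrogen. All three measured steps bear on this change, as each swaps one aromatic group for another on the same amide-type nitrogen: a number 5 percentage points higher from compound 1 to compound 2 (within the scatter), a number 3 percentage points higher from compound 1 to compound 3 (within the scatter) and a number 2 percentage points lower from compound 2 to compound 3 (within the scatter). None reached beyond the scatter, so no step beyond it is expected in this assay; the estimated step is a number 1 percentage points higher from compound 3 to compound 4 (within the scatter). Compound 4 is therefore expected to give 65%, in a range from 55% to 75%.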

Compound 4, largest response reached (Emax), in percent of the reference or control that the assay uses: 72%
For compound 4 the middle estimate is 7 percentage points below the measured one; low and high end bracket the measured number.
By their numbers in this assay, from the lowest: compounds 1, 3, 2 and 4 (each within the scatter of the next, the first and the last beyond it).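

In this assay, the amide-type nitrogen gives its first step beyond the scatter (a number 11 percentage points higher from compound 1 to compound 4 (beyond the scatter)), so 6-fluoropyridin-3-yl separates from phenyl as neither earlier fluoropyridinyl group did. It does not separate from those two groups, since both (a number 8 percentage points higher from compound 3 to compound 4 (within the scatter)) and (a number 6 percentage points higher from compound 2 to compound 4 (within the scatter)) stay within the scatter, and moving the same atoms around the ring therefore gives no firm difference. Nothing available explains the modest gain over phenyl. Still open, as far as these compounds go, is whether the fluorine matters at all, which unsubstituted pyridin-3-yl would test, and whether a methoxy group could replace it.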